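Inserting a methylene before the oxazolidinedione of compound 2

The source may report more compounds than this note shows. Statements on the series, on what has been measured and on what is new or still open speak of the compounds shown alone.

The series shares one core, seen in compound 1 `CC(C)[C@@H](C[C@H]1SC(=O)NC1=O)c1ccc(-c2ccc3cccc(F)c3c2)[nH]c1=O`, compound 2 `CC(C)[C@@H](c1ccc(-c2ccc3cccc(F)c3c2)[nH]c1=O)[C@H]1OC(=O)NC1=O` and compound 3 `CC(C)C(c1ccc(-c2ccc3cccc(F)c3c2)[nH]c1=O)C1SC(=O)NC1=O`. In a functional assay on CHO cells for antagonist activity at prostaglandin E2 receptor EP3 subtype (Homo sapiens), read by cAMP accumulation, with a stated time of 30 min (a lower number here means a stronger inhibitor, a higher number a weaker inhibitor), compound 1 gives 17 nM, compound 3 gives 110 nM, and compound 2 gives 92 nM. Compound 2 thus stands second highest of the three numbers; its nearest neighbour, compound 3, lies within the scatter, while compound 1 sits clearly below it, beyond the scatter.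

Compound 4 `CC(C)[C@H](C[C@@H]1OC(=O)NC1=O)c1ccc(-c2ccc3cccc(F)c3c2)[nH]c1=O` is not yet measured. It differs from compound 2 in one place: (2,4-dioxo-1,3-oxazolidin-5-yl)methyl in place of 2,4-dioxo-1,3-oxazolidin-5-yl on a saturated chain carbon bound to an aromatic carbon and a saturated chain carbon. Within the data shown here, no measured pair isolates this change. Still, compound 1 and compound 3 show that the analogue with a methylene between the chain carbon and the five-membered ring gives the lower number, and compound 3 carries no defined stereocentres. On that basis the writer expects compound 4 to fall below compound 2, with a step of a 3.1-fold lower number from compound 2 to compound 4 (0.49 log units; beyond the scatter) judged beyond the scatter. For compound 4 in this assay the estimate is 30 nM, with a range from 10 nM to 90 nM.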

Compound 4, half-maximal inhibitory concentration: 27 nM
Compound 4: the middle estimate sits 1.1-fold (0.05 log units) above what was measured; low and high end bracket the measured number.
By their numbers in this assay, from the lowest: compounds 1 and 4 (each within the scatter of the next); then compounds 2 and 3 (each within the scatter of the next).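

In this assay the inserted methylene gives a 3.4-fold lower number from compound 2 to compound 4 (0.53 log units; beyond the scatter), and this pair isolates the change on the saturated chain carbon bound to an aromatic carbon and a saturated chain carbon. Among these compounds, the number at this position therefore responds to (2,4-dioxo-1,3-oxazolidin-5-yl)methyl in place of 2,4-dioxo-1,3-oxazolidin-5-yl alone, which no earlier pair could show. Nothing given here accounts for the difference.

From the compounds shown here alone, whether a longer chain on the same carbon would lower the number further remains open. So does whether an amine or a carboxylic acid in place of the 2,4-dioxo-1,3-oxazolidin-5-yl ring, attached through the same methylene, would hold the number of compound 4.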